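Terminal swap on the chain of compound 1

The source may hold more compounds than are shown below. What is called first, only, known or untested is meant among the compounds shown, and "the series" means these compounds.

Within the data shown here, compound 1 `CC(C)(N)C(=O)N[C@H](COCc1ccccc1)c1nnnn1CCOC(=O)NCCCCCO` gives 14.6 nM in a functional assay on H4 cells with growth hormone secretagogue receptor type 1 (Homo sapiens) as the target, read by FLIPR (a higher number here means that more compound is needed for the effect, a lower number that less compound is needed), the higher of the two numbers measured so far; compound 2 `CC(=O)N[C@@H]1CCN(C(=O)OCCn2nnnc2[C@@H](COCc2ccccc2)NC(=O)C(C)(C)N)C1` gives 3.3 nM. Compound 3 `CC(C)(N)C(=O)N[C@H](COCc1ccccc1)c1nnnn1CCOC(=O)NCCCn1ccnc1` differs from compound 1 by 1H-imidazol-1-yl in place of 2-hydroxyethyl on a saturated chain carbon, three bonds along the chain from an amide-type nitrogen. Among the measured compounds shown here, the single measured step, a 4.4-fold lower number from compound 1 to compound 2 (0.65 log units; beyond the scatter), replaces the whole group on the carbonyl carbon and so bears only loosely on this change; no measured pair exchanges a terminal hydroxyl for an aromatic ring. The expectation is therefore a small step, a 1.5-fold lower number from compound 1 to compound 3 (0.16 log units; within the scatter), of uncertain direction. Compound 3 is estimated at 10 nM, range 3.5 nM to 30 nM.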

Compound 3, half-maximal effective concentration: 45.3 nM
Compound 3: the middle estimate sits 4.5-fold (0.66 log units) below what was measured, and the stated range ends below it.
By their numbers in this assay, from the lowest: compound 2; then compound 1; then compound 3.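

Exchanging the terminal 2-hydroxyethyl for 1H-imidazol-1-yl on this chain is not neutral in this assay and gives a 3.1-fold higher number from compound 1 to compound 3 (0.49 log units; beyond the scatter) in the direction opposite to the step seen with the 3-acetamidopyrrolidin-1-yl group. Among these compounds, replacing that group with (3-(1H-imidazol-1-yl)propyl)amino on the carbonyl carbon gives a 14-fold higher number from compound 2 to compound 3 (1.14 log units; beyond the scatter) and is the largest step so far. No supporting measurement accounts for either step.

Open, from the compounds shown here alone, is whether a primary amine or a carboxylic acid at the chain end would follow compound 1 or compound 3. Also open, going by these compounds, is how a longer chain carrying the 1H-imidazol-1-yl would compare.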